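A few compounds are considered here, and "the series" means these few. Any claim that something is new, unique, unknown or untested is made for them only; others in the source may bear on it.

Three related compounds have numbers in an ADME assay on L6 cells (Rattus norvegicus) for cytotoxicity, read by resazurin assay, with a stated time of 72 h; a lower number here means a stronger inhibitor, a higher number a weaker inhibitor. Compound 1 `CN1CCN(CCC(=O)NC2CC3(N(C)C)CC(c4ccccc4)C2C(c2ccccc2)C3)CC1` gives 95000 nM, compound 2 `CN1CCN(CC(=O)N2CCC3(N4CCCCC4)CC(c4ccccc4)C2C(c2ccccc2)C3)CC1` gives 177000 nM, and compound 3 `CN1CCN(CC(=O)NC2CC3(N(C)C)CC(c4ccccc4)C2C(c2ccccc2)C3)CC1` gives 66200 nM. Compound 1 falls between the other two numbers, and its gaps to both lie within the usual scatter of repeated measurements.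

Compound 4 `CN1CCN(CCC(=O)NC2CC3(N4CCCC4)CC(c4ccccc4)C2C(c2ccccc2)C3)CC1` has not yet been measured. It departs from compound 1 in one place, with pyrrolidin-1-yl in place of dimethylamino on a saturated ring carbon.

Among the measured compounds shown here, only one measured step changes a single place, a 1.4-fold lower number from compound 1 to compound 3 (0.16 log units; within the scatter). That step is small and lies within the scatter, but it alters the chain bearing the 4-methylpiperazin-1-yl group rather than the saturated ring carbon, so it bears on the new exchange only indirectly. Compound 2 differs from compound 1 in more than one place, so it offers no clean comparison. For the measured compounds named here, no measured pair isolates this exchange.

Going by the values given here, since the one clean step stayed within the scatter, no step beyond the scatter is expected in this assay, and no direction can be favoured: the estimated change is a 1.1-fold higher number from compound 1 to compound 4 (0.02 log units; within the scatter). Compound 4 is estimated at 100000 nM, with an expected range from 50000 nM to 190000 nM.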

Compound 4, half-maximal inhibitory concentration: 86700 nM
Beside the measured number, compound 4's estimate is 1.2-fold (0.06 log units) above it; measured number inside the range.
By their numbers in this assay, from the lowest: compounds 3, 4, 1 and 2 (each within the scatter of the next, the first and the last beyond it).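

Among the compounds shown here, replacing dimethylamino with pyrrolidin-1-yl on the saturated ring carbon gives the first direct reading of this position in this assay, where the step is a 1.1-fold lower number from compound 1 to compound 4 (0.04 log units; within the scatter) and so shows no real difference. The earlier step altered only the chain bearing the 4-methylpiperazin-1-yl group, whereas this one shows that the amine on the ring carbon can go from 3 heavy atoms to 5 and gain a five-membered non-aromatic ring without leaving the usual scatter. No measured evidence here accounts for this result.

On these data alone, the reading covers only these two groups at this position, so it remains open whether diethylamino, morpholin-4-yl or a carboxylic acid on the same ring carbon would also stay within the scatter in this assay or move the number beyond it. Compound 2 carries a piperidin-1-yl group, but it differs from compound 1 in more than one place and so cannot show what that larger ring does on its own.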